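From compound 3 to compound 4: chloro for fluoro

The source may report more compounds than this note shows. Statements on the series, on what has been measured and on what is new or still open speak of the compounds shown alone.

Of the compounds shown here, three on a shared core have been read in a functional assay on MCF7 cells (Homo sapiens) for antiproliferative activity, read by sulforhodamine B assay, with a stated time of 48 h; on this read-out higher numbers stand for weaker inhibition and lower numbers for stronger inhibition. Compound 1 `CCCN1CCN(c2ccc(S(=O)(=O)Oc3ccccc3C)cc2)C1=O` gives > 100000 nM, which is a limit of the assay. Compound 2 `CCCN1CCN(c2ccc(S(=O)(=O)Oc3c(Cl)cc(Cl)cc3Cl)cc2)C1=O` gives > 100000 nM, again a limit of the assay. Within the data shown here, compound 3 `CCCN1CCN(c2ccc(S(=O)(=O)Oc3cccc(F)c3)cc2)C1=O` gives 24000 nM, the only actual number in the set, as the other two readings rest on (the limit of > 100000 nM in this assay, at which 2 of the 3 values shown sit).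

Compound 4 `CCCN1CCN(c2ccc(S(=O)(=O)Oc3cccc(Cl)c3)cc2)C1=O` carries one change from compound 3: chloro in place of fluoro on an aromatic carbon. The exchange is chloro in place of fluoro on an aromatic carbon, meta to a large group.

Among the measured compounds shown here, two measured steps bear on it: an at least 4.1-fold lower number from compound 1 to compound 3 (0.61 log units; beyond the scatter) and an at least 4.1-fold lower number from compound 2 to compound 3 (0.61 log units; beyond the scatter). Each is bounded on one side only, and each replaces the whole group on the oxygen, so neither gives the size of a single halogen exchange. The 3-chlorophenyl of compound 4 stays closest to the 3-fluorophenyl of compound 3, so the expectation starts from 24000 nM. No step beyond the scatter is expected, and the estimated step is a 1.2-fold lower number from compound 3 to compound 4 (0.08 log units; within the scatter). The estimate for compound 4 is 20000 nM, with an expected range from 6000 nM to 70000 nM.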

Compound 4, half-maximal inhibitory concentration: 380 nM
For compound 4 the middle estimate is 53-fold (1.72 log units) above the measured one; measured number below the stated range.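

In this assay, among these compounds, the exchange of a single halogen on this aromatic carbon is enough to move the read-out a long way, with a 63-fold lower number from compound 3 to compound 4 (1.80 log units; beyond the scatter), whereas the earlier steps each replaced the whole group on the oxygen and gave only one-sided bounds. Among the compounds shown here, this is the first step with a size that can be read, and it shows that the position tolerates no simple equivalence between fluoro and chloro, since the two differ by far more than the scatter here. Compound 4 also stands well apart from the two other aryl groups, with an at least 260-fold lower number from compound 2 to compound 4 (2.42 log units; beyond the scatter) and an at least 260-fold lower number from compound 1 to compound 4 (2.42 log units; beyond the scatter), though both of these steps are open on one side, as compound 1 and compound 2 each sit at a limit of the assay: the limit of > 100000 nM in this assay, at which 2 of the 4 values shown sit.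

As far as these compounds go, whether bromo, methyl or trifluoromethyl on the same carbon would extend this step or reverse it stays open, as does the outcome of placing chloro elsewhere on the ring. Also open, from the compounds shown here alone, is whether the step holds with a longer chain in place of propyl on the shared core.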